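The compounds below may be only part of what the source reports. "The series", "measured", "known", "first", "only" and "open" are said of these compounds alone.

The measured compounds in an ADME assay on S9 fraction from liver (Homo sapiens) for metabolic stability, with a stated time of 1 h; on this read-out lower numbers stand for a less stable compound and higher numbers for a more stable compound:

compound 1 `N#Cc1cnc(NCc2cnccc2C(F)(F)F)cc1NC[C@H]1C[C@@H](O)C1`: 84%
compound 2 `N#Cc1cnc(NCc2cnccc2C(F)(F)F)cc1NC[C@H]1CC[C@H](O)CC1`: 32%

Among the measured compounds shown here, of these two numbers, compound 2 stands lowest; the only measured step, a number 52 percentage points lower from compound 1 to compound 2 (beyond the scatter), describes how it got there from compound 1, through a change of the saturated ring on the saturated chain carbon bound to a nitrogen on an aromatic ring. The next compound, compound 3 `N#Cc1cnc(NCc2cnccc2C(F)(F)F)cc1N[C@H]1CC[C@@H](C(N)=O)CC1`, keeps the shared core and alters the same region: 4-carbamoylcyclohexyl in place of (4-hydroxycyclohexyl)methyl on a nitrogen on an aromatic ring. The measured step of a number 52 percentage points lower from compound 1 to compound 2 (beyond the scatter) exchanged one saturated ring for another while keeping the hydroxyl and the link to the nitrogen; here the ring is kept, the hydroxyl becomes a carbamoyl group, and the ring itself sits on the nitrogen. For the measured compounds named here, no measured step covers either of those changes, so the only anchor is compound 2 itself. The step of a number 8 percentage points higher from compound 2 to compound 3 (within the scatter) is therefore expected to be small, not clearly beyond the scatter, with the direction uncertain. Compound 3 is estimated at 40% in this assay, within a range from 15% to 70%.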

Compound 3, percent of the compound remaining: 90%
Compound 3: the middle estimate sits 50 percentage points below what was measured; measured number outside the range, above it.
By their numbers in this assay, from the lowest: compound 2; then compounds 1 and 3 (each within the scatter of the next).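

In this assay, putting 4-carbamoylcyclohexyl in place of (4-hydroxycyclohexyl)methyl on the nitrogen on an aromatic ring gives a number 58 percentage points higher from compound 2 to compound 3 (beyond the scatter), so a six-membered non-aromatic ring of carbon only at this position does not by itself go with a low number. The step of a number 6 percentage points higher from compound 1 to compound 3 (within the scatter) means that 4-carbamoylcyclohexyl and (3-hydroxycyclobutyl)methyl cannot be told apart on this read-out, so the low number of compound 2 belongs to its own group and not to every saturated ring placed here. No available evidence explains this difference between the groups.

This change alters two things at once, since the hydroxyl gives way to a carbamoyl group and the ring moves from a saturated chain carbon directly onto the nitrogen, and the compounds shown cannot separate the two. A 4-hydroxycyclohexyl group sitting directly on the nitrogen would address that question, while a 4-aminocyclohexyl or 4-carboxycyclohexyl group would show how the number responds to other groups on the same ring.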